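This account rests on a few compounds, and the source may have more. Where it says the series, first, only, none or still open, it means among the compounds named here.

Measured so far in a functional assay on SGC-7901 cells (Homo sapiens) for inhibition, read by MTT assay, with a stated time of 24 h; a lower number here means a stronger inhibitor, a higher number a weaker inhibitor:
compound 1 `CC1(C)[C@H]2CC[C@]1(C)N(Cc1cn(-c3cccc(F)c3)nn1)C(=O)C2` gives 530 nM
compound 2 `CC1(C)[C@H]2CC[C@]1(C)N(Cc1cn(-c3ccc(C#N)cc3)nn1)C(=O)C2` gives 500 nM
compound 3 `CC1(C)[C@H]2CC[C@]1(C)N(Cc1cn(-c3ccccc3C#N)nn1)C(=O)C2` gives 260 nM

Compound 1 stands at the highest number of the three. The nearest of the others is reached by a 1.1-fold lower number from compound 1 to compound 2 (0.03 log units; within the scatter), a step within the scatter; the furthest by a 2.0-fold lower number from compound 1 to compound 3 (0.31 log units; beyond the scatter), a modest step beyond it. The remaining pair, a 1.9-fold lower number from compound 2 to compound 3 (0.28 log units; within the scatter), again stays within the scatter. So far only the 2-cyanophenyl has moved the number noticeably.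

Compound 4 `CC1(C)[C@H]2CC[C@]1(C)N(Cc1cn(-c3ccc(O)cc3)nn1)C(=O)C2` has not yet been measured in this assay. It differs from compound 1 in one place: 4-hydroxyphenyl in place of 3-fluorophenyl on an aromatic nitrogen. The measured step that bears most directly on it is the one in which 4-cyanophenyl took the place of 3-fluorophenyl, a 1.1-fold lower number from compound 1 to compound 2 (0.03 log units; within the scatter), which lay within the scatter. Within the data shown here, no measured compound carries a hydrogen-bond donor on this phenyl, so the effect of the hydroxyl itself has no precedent here. Among the measured compounds shown here, on the one comparable step, the expected change from compound 1 is small and not beyond the scatter, a 1.2-fold lower number from compound 1 to compound 4 (0.07 log units; within the scatter). For compound 4 the expected value in this assay is 450 nM, with a range from 200 nM to 1100 nM.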

Compound 4, half-maximal inhibitory concentration: 330 nM
Estimate against measurement, compound 4: 1.4-fold (0.13 log units) above; the range from low to high includes it.
By their numbers in this assay, from the lowest: compounds 3, 4, 2 and 1 (each within the scatter of the next, the first and the last beyond it).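

In this assay, compound 4 carries a hydrogen-bond donor on the phenyl at the aromatic nitrogen, which compound 1, compound 2 and compound 3 lack, and the number stays within the scatter of both compounds with the closest comparison: a 1.6-fold lower number from compound 1 to compound 4 (0.21 log units; within the scatter) for the change from 3-fluorophenyl, and a 1.5-fold lower number from compound 2 to compound 4 (0.18 log units; within the scatter) for hydroxy in place of cyano on the same aromatic carbon. Against the 2-cyanophenyl, the reading is a 1.3-fold higher number from compound 3 to compound 4 (0.10 log units; within the scatter) and also lies within the scatter, so compound 4 cannot be separated from any of the other three, even though compound 1 and compound 3 are separated from each other. This position therefore accepts a hydroxy group, a nitrile or a fluorine on the phenyl without any step from compound 4 leaving the scatter, and no measured property is available to account for these numbers.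

From the compounds shown here alone, whether the hydroxy group itself matters stays open, as a methoxy group, an amine or a carboxylic acid on the same aromatic carbon would show whether other groups there read like compound 4. Also open, going by these compounds, is whether the hydroxy group would read the same elsewhere on the phenyl, and whether the phenyl can be replaced altogether by a saturated ring such as cyclohexyl.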